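A few compounds are considered here, and "the series" means these few. Any claim that something is new, unique, unknown or untested is made for them only; others in the source may bear on it.

In a functional assay on the whole organism for inhibition, with Rattus norvegicus as the target, read by cytopathic effect and paw edema, at a dose of 100 mg/kg by the oral route (a lower number here means less inhibition, a higher number more inhibition at the dose given (going by the name of the read-out)), compound 1 `CNC(=O)c1c(O)c2cccnc2n(-c2ccccc2)c1=O` gives 21%, compound 2 `Cc1ccc(NC(=O)c2c(O)c3cccnc3n(-c3ccccc3)c2=O)cc1` gives 2.2%, and compound 3 `O=C(Nc1cccc([N+](=O)[O-])c1)c1c(O)c2cccnc2n(-c2ccccc2)c1=O` gives 7.4%. Compound 3 thus stands second highest of the three numbers, within the scatter of compound 2 and beyond the scatter below compound 1. Compound 4 `O=C(NCc1cccnc1)c1c(O)c2cccnc2n(-c2ccccc2)c1=O` differs from compound 3 by (pyridin-3-yl)methyl in place of 3-nitrophenyl on an amide-type nitrogen. Among the compounds with values here, the steps that bear on this are a number 13.6 percentage points lower from compound 1 to compound 3 (beyond the scatter) and a number 18.8 percentage points lower from compound 1 to compound 2 (beyond the scatter), both modest falls on exchanging methyl for an aryl group, while a number 5.2 percentage points higher from compound 2 to compound 3 (within the scatter) lies within the scatter. The entering (pyridin-3-yl)methyl is neither the methyl of compound 1 nor an aryl group like those of compounds 2 and 3, so a small rise is expected. Compound 4 is therefore estimated at 12%, between 2% and 25%, which would mean a step of a number 4.6 percentage points higher from compound 3 to compound 4 (within the scatter).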

Compound 4, a percentage reported as inhibition, in the whole organism at one dose (the size of the read-out at that dose, not a potency): 14.7%
The estimate for compound 4 lay 2.7 percentage points below the measured number, and the stated range covers the measured number.
By their numbers in this assay, from the lowest: compounds 2, 3, 4 and 1 (each within the scatter of the next, the first and the last beyond it).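

Within the data shown here, the (pyridin-3-yl)methyl group is the first at this amide-type nitrogen to stand beyond the scatter above an aryl group, here 4-methylphenyl (a number 12.5 percentage points higher from compound 2 to compound 4 (beyond the scatter)), though not above 3-nitrophenyl (a number 7.3 percentage points higher from compound 3 to compound 4 (within the scatter)). Adding pyridin-3-yl to the saturated chain carbon of compound 1 brings no fall beyond the scatter (a number 6.3 percentage points lower from compound 1 to compound 4 (within the scatter)), so a ring can be carried on this chain without a clear loss. The data offered here give no explanation for these steps.

From the compounds shown here alone, whether benzyl or a longer chain bearing pyridin-3-yl would read differently remains open.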